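The source may hold more compounds than are shown below. What is called first, only, known or untested is meant among the compounds shown, and "the series" means these compounds.

Measured compounds:
Compound 1 `CN1CCCC(NC(=O)c2ccc(C(F)(F)F)cc2Br)(c2ccccc2)C1` gives 300 nM in an assay on cells for inhibition of sodium- and chloride-dependent glycine transporter 1 (Homo sapiens); a lower number here means that less compound is needed, a higher number that more compound is needed for the effect.
Compound 2 `COc1cc(C(F)(F)F)cc(SC)c1C(=O)NC1(c2ccc(Cl)cc2)CCCN(C)C1` gives 28 nM in this assay.

For the measured compounds named here, of the two numbers, compound 2 has the lower one; the gap to compound 1 lies beyond the usual scatter of repeated measurements, so compound 2 is the one of the pair that needs less material for the effect. Going by the values given here, no single-change step between these two measured compounds has been worked out, so what their two values show is all that can be said of them.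

Compound 3 `COc1cc(C(F)(F)F)cc(SC)c1C(=O)NC1(c2cccnc2)CCCN(C)C1` has not yet been measured in this assay. It differs from compound 2 in one place: pyridin-3-yl in place of 4-chlorophenyl on a saturated ring carbon. Among the compounds with values here, no measured step covers such a change, so the expectation rests on compound 2 alone. A modest move toward a higher number is expected, and the step from compound 2 to compound 3 is estimated at a 2.9-fold higher number from compound 2 to compound 3 (0.46 log units; beyond the scatter). For compound 3 the value expected in this assay is 80 nM, with a range from 25 nM to 300 nM.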

Compound 3, half-maximal effective concentration: 54 nM
Beside the measured number, compound 3's estimate is 1.5-fold (0.17 log units) above it; low and high end bracket the measured number.
By their numbers in this assay, from the lowest: compounds 2 and 3 (each within the scatter of the next); then compound 1.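

Replacing the 4-chlorophenyl on the saturated ring carbon with pyridin-3-yl gives a 1.9-fold higher number from compound 2 to compound 3 (0.29 log units; within the scatter) in this assay. For the compounds shown here, this is the first single-change step, and it shows that neither the chlorine nor an all-carbon aromatic ring is needed at this position to keep the number level with that of compound 2. The same step brings in a ring nitrogen and a hydrogen-bond acceptor without a change that can be told apart from repeat measurement, but no measurement shown here explains this result.

It remains open whether the location of the ring nitrogen matters, as pyridin-2-yl and pyridin-4-yl do not appear among these compounds. Nor do they show how a 4-fluorophenyl or a 4-methoxyphenyl would fare at this position on the core of compound 2.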